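Trading a piperidine for a methoxy on an anilinopyrimidine

The compounds below may be only part of what the source reports. "The series", "measured", "known", "first", "only" and "open" are said of these compounds alone.

Measured compounds:
compound 1 `COc1cccc(Nc2nccc(-c3ccsc3)n2)c1` gives 1800 nM
compound 2 `COc1cccc(Nc2nccc(-c3cc(C)oc3C)n2)c1` gives 5800 nM
compound 3 `CC1CCN(c2ccc(Nc3nccc(-c4cccnc4)n3)cc2)CC1` gives 500 nM

These three compounds were tested in a functional assay for inhibition, with Homo sapiens as the target; a higher number here means a weaker inhibitor, a lower number a stronger inhibitor. Among them compound 3 stands lowest, which makes it the strongest inhibitor of the set; compound 1 sits nearest to it, and compound 2 is furthest away. Within the data shown here, the only single change measured so far, a 3.2-fold higher number from compound 1 to compound 2 (0.51 log units; beyond the scatter), concerns the ring attached to the shared core, not the aniline side.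

Compound 4 `COc1ccc(Nc2nccc(-c3cccnc3)n2)cc1` is the untested compound. It differs from compound 3 as follows: methoxy in place of 4-methylpiperidin-1-yl on an aromatic carbon. Among the measured compounds shown here, no measured step touches this position, so nothing in the data bears directly on it; compound 1 carries a methoxy too, but its other ring differs as well, and its value can only be read as a rough pointer. Removing a large group and leaving a small one is expected to cost some potency, so for compound 4 the expected step is a 3.0-fold higher number from compound 3 to compound 4 (0.48 log units; beyond the scatter). Compound 4 is estimated at 1500 nM, with a range from 500 nM to 5000 nM.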

Compound 4, half-maximal inhibitory concentration: 1700 nM
Compound 4: the middle estimate sits 1.1-fold (0.05 log units) below what was measured; the range from low to high includes it.
By their numbers in this assay, from the lowest: compound 3; then compounds 4 and 1 (each within the scatter of the next); then compound 2.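

In this assay, among these compounds, replacing 4-methylpiperidin-1-yl with methoxy gives a 3.4-fold higher number from compound 3 to compound 4 (0.53 log units; beyond the scatter), the first measured change on this side of the molecule. It shows that the group on this six-membered aromatic ring of carbon only can move the number beyond the scatter, and that here the compound with 4-methylpiperidin-1-yl is the stronger inhibitor of the pair. Nothing available explains why this swap has this effect.

Going by these compounds, it remains open whether the ring, its nitrogen, its methyl group or simply the larger number of atoms matters, and a morpholine or a dimethylamino group in this place would help to separate these possibilities. Also open, on these data alone, is whether 4-methylpiperidin-1-yl would give a similar step alongside thiophen-3-yl or 2,5-dimethylfuran-3-yl on the shared core.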